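The source may hold more compounds than are shown below. What is called first, only, known or untested is meant among the compounds shown, and "the series" means these compounds.

Of the compounds shown here, three have so far been measured in a functional assay on a cell-free system (plasma, Homo sapiens), with a stated time of 3 min; on this read-out higher numbers stand for weaker inhibition and lower numbers for stronger inhibition. Compound 1 (`O=C(NCc1cc(Cl)ccc1-n1cnnn1)[C@@H]1CC=NN1C(=O)[C@H](O)c1ccccc1F`) gives 1100 nM there, compound 2 (`O=C(NCc1cc(Cl)ccc1-n1cnnn1)[C@@H]1[C@@H]2C[C@@H]2CN1C(=O)[C@H](O)Cc1ccccn1`) gives 1700 nM and compound 3 (`O=C(NCc1cc(Cl)ccc1-n1cnnn1)[C@@H]1C[C@H]2C[C@H]2N1C(=O)[C@H](O)CC1CC1`) gives 850 nM in the same test. Compound 1 thus lies within the scatter of both others, and the numbers place it in no order among them.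

The next compound, compound 4 (`CCCC[C@@H](O)C(=O)N1N=CC[C@H]1C(=O)NCc1cc(Cl)ccc1-n1cnnn1`), keeps the core of compound 1 and changes one group (butyl in place of 2-fluorophenyl on a saturated chain carbon bound to a carbonyl carbon and an oxygen on a saturated carbon), with butyl in place of 2-fluorophenyl on a saturated chain carbon bound to a carbonyl carbon and an oxygen on a saturated carbon.

Within the data shown here, no two measured compounds differ in one place only, so the data hold no direct precedent for this change. The nearest hint is compound 3, which has no aromatic ring on the matching carbon and gives 850 nM on a different core. In this assay the change is therefore expected to produce no shift beyond the scatter, and no firm direction is expected. The expected result is a 1.2-fold higher number from compound 1 to compound 4 (0.07 log units; within the scatter) as a small step. Compound 4 is estimated at 1300 nM with an expected range from 450 nM to 3800 nM in this test.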

Compound 4, half-maximal inhibitory concentration: 610 nM
Compound 4: middle estimate off by 2.1-fold (0.33 log units), on the high side; the measured number falls inside the stated range.
By their numbers in this assay, from the lowest: compounds 4, 3, 1 and 2 (each within the scatter of the next, the first and the last beyond it).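

Among these compounds, the pair gives the first direct reading at this position: on the shared core, butyl replaces 2-fluorophenyl on a saturated chain carbon bound to a carbonyl carbon and an oxygen on a saturated carbon, and this assay shows a 1.8-fold lower number from compound 1 to compound 4 (0.26 log units; within the scatter) for this swap. The aromatic ring and its fluorine can therefore give way to an open chain with fewer heavy atoms without a shift that can be told from the scatter, so in this pair the ring is not needed to hold the number at this level. Nothing at hand bears on why the two compounds lie this close.

The compounds shown leave open whether propyl, a longer chain such as hexyl, or a chain ending in an amine or a carboxylic acid would move the number beyond the scatter at this place. They also leave open whether butyl would fare the same way on the core of compound 2 or the core of compound 3, as neither of these is paired with a compound that differs from it in this group alone.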